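The source may hold more compounds than are shown below. What is called first, only, known or untested is meant among the compounds shown, and "the series" means these compounds.

Within the data shown here, compound 2 `O=C(Cn1c(=O)c(/C=C\c2ccncc2)nc2ccccc21)Nc1ccc(F)cc1` is the one compound that gives a number in a functional assay on PC-3 cells (Homo sapiens) for inhibition, read by MTT assay, with a stated time of 24 h; on this read-out lower numbers stand for stronger inhibition and higher numbers for weaker inhibition: in that read-out compound 2 gives 59900 nM. Compound 1 `O=C(Cn1c(=O)c(/C=C\c2ccncc2)nc2ccccc21)Nc1ccccc1`, which carries hydrogen where compound 2 carries fluoro, reaches only a limit of this assay, and compound 1 gives > 100000 nM. Among the measured compounds shown here, the single measured step, an at least 1.6-fold lower number from compound 1 to compound 2 (0.22 log units; that floor lies within the scatter), rests on that limit of > 100000 nM in this assay, at which 1 of the 2 values shown sits, and so sets only a floor. Compound 3 `O=C(Cn1c(=O)c(/C=C\c2ccncc2)nc2ccccc21)Nc1ccc(Cl)cc1` differs from compound 2 by chloro in place of fluoro on an aromatic carbon. For the measured compounds named here, no measured step bears directly on this exchange; the only step, from hydrogen to fluoro, is no larger than its floor. The account therefore expects at most a modest change in this assay, in either direction and plausibly none beyond the scatter, so the estimated step is a 1.5-fold lower number from compound 2 to compound 3 (0.18 log units; within the scatter). Compound 3 is estimated at 40000 nM, between 15000 nM and 100000 nM.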

Compound 3, half-maximal inhibitory concentration: > 100000 nM
Compound 3 gave a limit, no number; the forecaster's own chance of this, stated with the estimate: 20%; middle value at least 2.5-fold (0.39 log units) from the limit.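

In this assay compound 3 reaches only a limit, > 100000 nM, and not a number. Chloro at this place, para to a large group, does not keep the readable value seen with fluoro: the result is an at least 1.6-fold higher number from compound 2 to compound 3 (0.22 log units; that floor lies within the scatter), which is a floor only, so the two halogens are not shown to differ beyond the scatter. The step between compound 1 and compound 3 cannot be read, and with this result the limit now holds most of the series: the limit of > 100000 nM in this assay, at which 2 of the 3 values shown sit.

On these data alone, whether a methoxy group, a nitrile, a trifluoromethyl group or an amine at this place would give a number in this assay stays open. Also open, as far as these compounds go, is whether fluoro truly differs from hydrogen or chloro here by more than the scatter.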